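Sulfonamide series on the shared core: chloro to methoxy

The source may hold more compounds than are shown below. What is called first, only, known or untested is meant among the compounds shown, and "the series" means these compounds.

Measured so far:
- compound 1 `Cc1cc2cc(NS(=O)(=O)c3cc(C(=O)NO)ccc3Cl)ccc2n(C)c1=O` — in a functional assay on HL-60 cells (Homo sapiens) for antiproliferative activity, tested at 100 uM (on this read-out lower numbers stand for a weaker effect and higher numbers for a stronger effect at the one concentration tested), compound 1 gives 33%
- compound 2 `COC(=O)c1ccc(CS(=O)(=O)Nc2ccc3c(c2)cc(C)c(=O)n3C)cc1` — in this assay compound 2 gives 78%
- compound 3 `COC(=O)c1ccc(S(=O)(=O)Nc2ccc3c(c2)cc(C)c(=O)n3C)c(OC)c1` — in this assay compound 3 gives 68%

Compound 1 stands lowest of the three numbers in this assay. Its nearest neighbour is compound 3, whose number lies higher by an amount beyond the scatter, and compound 2 lies higher still, also beyond the scatter. For the measured compounds named here, no step between two measured compounds differing in one place is available, so nothing in these three numbers isolates the effect of any single change; compound 3 carries a methoxy but differs from compound 1 in more than one place.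

Compound 4 `COc1ccc(C(=O)NO)cc1S(=O)(=O)Nc1ccc2c(c1)cc(C)c(=O)n2C` is not yet measured. It differs from compound 1 as follows: methoxy in place of chloro on an aromatic carbon. Going by the values given here, with no matching step among the measured compounds, the expected direction rests on nothing firmer than the general spread of the series. A modest upward step from compound 1 to compound 4 is expected, a number 12 percentage points higher from compound 1 to compound 4 (beyond the scatter), with a range wide enough to include no change beyond the scatter. For compound 4 in this assay the estimate is 45%, between 20% and 70%.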

Compound 4, a percentage reported as inhibition, at one concentration (the size of the read-out at that concentration, not a potency): 39%
For compound 4 the middle estimate is 6 percentage points above the measured one, within the range that was stated.
By their numbers in this assay, from the lowest: compounds 1 and 4 (each within the scatter of the next); then compounds 3 and 2 (each within the scatter of the next).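

In this assay the series now has its first step between compounds differing in one place: a number 6 percentage points higher from compound 1 to compound 4 (within the scatter). Methoxy in place of chloro, ortho to a large group and para to a hydroxycarbamoyl group, therefore does not separate the two compounds on this read-out, even with one more heavy atom and one more hydrogen-bond acceptor counted for the entering group. Nothing measured bears on why the two numbers stay within the scatter of each other.

Going by these compounds, it remains open whether a different group at this position, such as an amine, a carboxylic acid or a longer alkoxy chain, would move the number beyond the scatter. Also open, on these data alone, is whether methoxy in place of chloro would read the same with a methyl ester in place of the hydroxycarbamoyl group.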